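Testing a Phenyl Amide Against a Cytotoxicity Limit

The source may report more compounds than this note shows. Statements on the series, on what has been measured and on what is new or still open speak of the compounds shown alone.

Compound 1, `C=CC1=C(C(=O)NCc2ccc(Cl)cc2)C(c2ccc(OC)c(OC)c2)OC1`, was examined in a functional assay on HeLa cells (Homo sapiens) for cytotoxicity, read by MTT assay, with a stated time of 24 h; a lower number here means a stronger inhibitor, a higher number a weaker inhibitor. In this assay compound 1 gives > 100000 nM, which is a limit of the assay rather than a number. Compound 2, `C=CC1=C(C(=O)NCc2ccc(Cl)cc2)C(c2ccc(OC)cc2)OC1`, is reached from compound 1 by a step that the two limits leave unreadable from compound 1 to compound 2. Compound 2 gives > 100000 nM, which is a limit of the assay. Compound 3, `C=CC1=C(C(=O)Nc2ccc(OCC)cc2)C(c2ccc(OC)cc2)OC1`, is reached from compound 2 by a step that the two limits leave unreadable from compound 2 to compound 3. Compound 3 gives > 100000 nM, which is a limit of the assay. The common feature is the limit of > 100000 nM in this assay, at which 3 of the 3 values shown sit, so no readable number exists among the three.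

Compound 4, `C=CC1=C(C(=O)Nc2ccccc2)C(c2ccc(OC)c(OC)c2)OC1`, has not yet been measured. It differs from compound 1 by phenyl in place of 4-chlorobenzyl on an amide-type nitrogen. The measured step that touches the same position is a step that the two limits leave unreadable from compound 2 to compound 3, whose size could not be read. Within the data shown here, because the limit of > 100000 nM in this assay, at which 3 of the 3 values shown sit, holds for every value so far, the expectation for compound 4 is a further limit rather than a readable number. The estimated step that the limit leaves unreadable from compound 1 to compound 4 is expected to be none beyond the scatter. Compound 4 is expected to give 150000 nM, with a range from 50000 nM to 500000 nM.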

Compound 4, half-maximal inhibitory concentration: 5030 nM
Estimate against measurement, compound 4: 30-fold (1.47 log units) above; measured number below the stated range.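

In this assay, the group on the amide-type nitrogen proves able to move the result: phenyl in place of 4-chlorobenzyl gives an at least 19-fold lower number from compound 1 to compound 4 (1.29 log units; beyond the scatter). Among these compounds, the earlier steps cannot be read, so this is the first change with a size, and it shows that the shared core can give a readable number when this group changes. This rests on a single pair, and compound 4 stands alone against the rest of the set: the limit of > 100000 nM in this assay, at which 3 of the 4 values shown sit.

The change removes both the chlorine and the carbon link to the ring, so the compounds shown leave open which of the two accounts for the step. From the compounds shown here alone, a plain benzyl or a 4-chlorophenyl group on the same nitrogen would separate them, and an amine or carboxylic acid on the phenyl ring remains unexplored here.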